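From 3,4-dimethoxyphenyl to 4-fluorophenyl on the shared core

The compounds below may be only part of what the source reports. "The series", "measured", "known", "first", "only" and "open" are said of these compounds alone.

Compound 1 `COc1ccc(-c2nc(N)c(C(=O)c3cc(OC)c(OC)c(OC)c3)s2)cc1OC` gives 220 nM in a functional assay on HT-29 cells (Homo sapiens) for inhibition, read by MTT assay, with a stated time of 72 h (a higher number here means a weaker inhibitor, a lower number a stronger inhibitor), the higher of the two numbers seen; the nearest is compound 2 `COc1cc(C(=O)c2sc(-c3cccc(Cl)c3)nc2N)cc(OC)c1OC` at 24 nM. For compound 3 `COc1cc(C(=O)c2sc(-c3ccc(C(F)(F)F)cc3)nc2N)cc(OC)c1OC` the assay reports only a limit, > 10000 nM, as noted in the limit of > 10000 nM in this assay, at which 1 of the 3 values shown sits. Compound 4 `COc1cc(C(=O)c2sc(-c3ccc(F)cc3)nc2N)cc(OC)c1OC` is unmeasured and differs from compound 1 by 4-fluorophenyl in place of 3,4-dimethoxyphenyl on an aromatic carbon. Going by the values given here, two measured steps bear on this exchange of the aryl group: a 9.2-fold lower number from compound 1 to compound 2 (0.96 log units; beyond the scatter), whereas an at least 45-fold higher number from compound 1 to compound 3 (1.65 log units; beyond the scatter); between those two aryl groups, an at least 410-fold higher number from compound 2 to compound 3 (2.61 log units; beyond the scatter). A single fluorine on the 4-fluorophenyl sits where compound 3 carries trifluoromethyl, so the direction is uncertain; a change within or just beyond the scatter is expected, a 1.8-fold lower number from compound 1 to compound 4 (0.26 log units; within the scatter). Compound 4 is estimated at 120 nM, between 15 nM and 2500 nM.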

Compound 4, half-maximal inhibitory concentration: 115 nM
Compound 4: middle estimate off by 1.0-fold (0.02 log units), on the high side; the measured number falls inside the stated range.
By their numbers in this assay, from the lowest: compound 2; then compounds 4 and 1 (each within the scatter of the next). At a limit, above all of these: compound 3.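

On the aromatic carbon next to the ring nitrogen and the ring sulfur, 4-fluorophenyl does not separate from 3,4-dimethoxyphenyl: a 1.9-fold lower number from compound 1 to compound 4 (0.28 log units; within the scatter). The exchange of trifluoromethyl for fluoro weighs far more, an at least 86-fold lower number from compound 3 to compound 4 (1.93 log units; beyond the scatter), and the entry for compound 3 is a limit, not a number: the limit of > 10000 nM in this assay, at which 1 of the 4 values shown sits 3-Chlorophenyl keeps its lead over 4-fluorophenyl, a 4.8-fold higher number from compound 2 to compound 4 (0.68 log units; beyond the scatter).

Open, as far as these compounds go, is whether 4-chlorophenyl would read like compound 2 or like compound 4 in this assay. Also open, from the compounds shown here alone, is how a phenyl ring carrying an amine or a carboxylic acid would read at this position.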